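The source may report more compounds than this note shows. Statements on the series, on what has been measured and on what is new or still open speak of the compounds shown alone.

Working notes on the series. Three compounds with the shared core have been run in a functional assay on Ehrlich cells (Mus musculus) for cytotoxicity; a higher number here means a weaker inhibitor, a lower number a stronger inhibitor: compound 1 `COc1cc(N2C(N)=C(C#N)C(c3ccc(OC)c4ccccc34)C3=C2CC(C)(C)CC3=O)cc(OC)c1OC`, compound 2 `COc1cc(N2C(N)=C(C#N)C(c3ccc(O)cc3)C3=C2CC(C)(C)CC3=O)cc(OC)c1OC` and compound 3 `COc1cc(N2C(N)=C(C#N)C(c3ccccc3Cl)C3=C2CC(C)(C)CC3=O)cc(OC)c1OC`. Compound 1 is reported as "not active" (no number reported), with no half-maximal inhibitory concentration given. Compound 2 gives 75800 nM. Compound 3 is also reported as "not active" (no number reported) and has no number, so compound 3 cannot be placed against compound 2 beyond the fact that compound 2 returned a value in this assay and compound 3 did not. Compound 4 `COc1cc(N2C(N)=C(C#N)C(c3ccccc3O)C3=C2CC(C)(C)CC3=O)cc(OC)c1OC` is still to be measured in this assay.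

The change from compound 3 to compound 4: hydroxy in place of chloro on an aromatic carbon. It exchanges the 2-chlorophenyl for a 2-hydroxyphenyl.

For the measured compounds named here, no step between two measured compounds is available, so the size of the move from compound 3 to compound 4 in this assay has no anchor. Going by the values given here, the only other hydroxy-bearing member, compound 2 at 75800 nM, sits at a weak level, and compound 3 gave no number at all. The expectation is therefore a weak result, with a real chance that the assay again reports no number and, if it does report one, no step beyond the scatter in either direction.

Compound 4 is expected near 90000 nM, within 30000 nM to 300000 nM.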

Compound 4, half-maximal inhibitory concentration: "not active" (no number reported)
Nothing numeric was reported for compound 4, and the estimate cannot be compared.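

In this assay, for the compounds shown here, neither compound 3 nor compound 4 has a number, so no step between the 2-chlorophenyl and 2-hydroxyphenyl members can be read. No measurement shown bears on this result. The compounds shown leave open how the position of the hydroxy group relates to activity, since compound 2 alone gives a value, 75800 nM, and it differs from compound 4 in more than one respect.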